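This account rests on a few compounds, and the source may have more. Where it says the series, first, only, none or still open, it means among the compounds named here.

Within the data shown here, compound 1 `Cc1cc(-c2ccc(F)nc2F)nn(Cc2ccc(Cl)cc2)c1=O` is the only member of the series with a number in an ADME assay on HepG2 2.2.15 cells (Homo sapiens) for cytotoxicity, read by MTT assay, with a stated time of 8 days; a lower number here means that less compound is tolerated, a higher number that more compound is tolerated; compound 1 gives 83800 nM. Compound 2 `N#Cc1ccc(Cn2nc(-c3cc(Cl)c(NC[C@H](O)CO)nc3F)c3ccccc3c2=O)cc1` sits at a limit of the measurement in this assay, compound 2 giving > 100000 nM. Compound 3 `N#Cc1ccc(Cn2nc(-c3cc(Cl)c(NCC(O)CO)nc3F)c3ccccc3c2=O)cc1` also sits at a limit in this assay, compound 3 giving > 100000 nM. Among the measured compounds shown here, the single measured step, a step that the two limits leave unreadable from compound 2 to compound 3, cannot be read because of the limit of > 100000 nM in this assay, at which 2 of the 3 values shown sit; the two structures differ only in the fact that one of compounds 2 and 3 is drawn with a defined configuration and the other without, at the place where they differ.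

Compound 4 `CC(C)c1cc(-c2ccc(F)nc2F)nn(Cc2ccc(Cl)cc2)c1=O` arises from compound 1 by isopropyl in place of methyl on an aromatic carbon. For the measured compounds named here, no measured step touches this position of the shared core or an exchange of one alkyl for another, so none of the measured steps bears on the change; the two limits give no size to compare. With nothing to point either way, the step is expected to stay within the usual scatter. Compound 4 is therefore estimated at 70000 nM, with a range from 35000 nM to 140000 nM. The expected step is a 1.2-fold lower number from compound 1 to compound 4 (0.08 log units; within the scatter), a change within the scatter.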

Compound 4, half-maximal cytotoxic concentration: 56700 nM
Beside the measured number, compound 4's estimate is 1.2-fold (0.09 log units) above it, within the range that was stated.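

In this assay, among these compounds, the aromatic carbon opposite the ring nitrogen now has a readable step, which the earlier compounds did not provide: a 1.5-fold lower number from compound 1 to compound 4 (0.17 log units; within the scatter). Exchanging methyl for isopropyl at this place therefore leaves compound 1 and compound 4 indistinguishable in this read-out, and the series gains its first information on an exchange of one alkyl for another. Nothing measured here bears on the size of this step.

Going by these compounds, whether a longer chain such as n-butyl, an amine or a carboxylic acid on this aromatic carbon would also stay within the scatter remains open. Also open, on these data alone, is whether the exchange of methyl for isopropyl would read the same with a group other than the 4-chlorobenzyl group or the 2,6-difluoropyridin-3-yl group on the shared core.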